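Fluoro added to the aryl ether: compound 3 to compound 4

A few compounds are considered here, and "the series" means these few. Any claim that something is new, unique, unknown or untested is made for them only; others in the source may bear on it.

Among the compounds with values here, compound 1 `Cc1nn(C)c(Oc2ccc(Br)cc2)c1/C=N\CCCCCOc1cc2oc(=O)cc(C)c2cc1Cl` is the one member of the series with a number in a functional assay on HepG2 cells (Homo sapiens) for antiproliferative activity, read by MTT assay, with a stated time of 72 h (a higher number here means a weaker inhibitor, a lower number a stronger inhibitor), and compound 1 gives 13800 nM there. Compound 2 `Cc1nn(C)c(Oc2ccc(I)cc2)c1/C=N\CCCCCOc1cc2oc(=O)cc(C)c2cc1Cl` reaches only a limit in this assay, > 25000 nM. Within the data shown here, the one measured step, an at least 1.8-fold higher number from compound 1 to compound 2 (0.25 log units; that floor lies within the scatter), has a floor that lies within the scatter. Compound 3 `Cc1nn(C)c(Oc2ccccc2F)c1/C=N\CCCCCCOc1cc2oc(=O)cc(C)c2cc1Cl` also returns only a limit in this assay, > 25000 nM. Compound 3 thus stands at the limit of > 25000 nM in this assay, at which 2 of the 3 values shown sit, with no number of its own. Compound 4 `Cc1nn(C)c(Oc2cccc(F)c2F)c1/C=N\CCCCCCOc1cc2oc(=O)cc(C)c2cc1Cl` differs from compound 3 by fluoro in place of hydrogen on an aromatic carbon. Among the measured compounds shown here, no measured step adds a fluoro group; the single step of an at least 1.8-fold higher number from compound 1 to compound 2 (0.25 log units; that floor lies within the scatter) exchanges one halogen for another and stays within the scatter. With compound 3 at a limit, the step that the limit leaves unreadable from compound 3 to compound 4 is expected to be nothing beyond the scatter. Compound 4 is therefore estimated at about 30000 nM in this assay, very likely again only a limit, within 12000 nM to 80000 nM.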

Compound 4, half-maximal inhibitory concentration: > 25000 nM
Compound 4 gave a limit, no number; the forecaster's own chance of this, stated with the estimate: 70%; the middle value lies beyond the limit too.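

Compound 3 and compound 4 both give only a limit in this assay, so no step can be read between them. The compounds shown leave open how 2-fluorophenoxy and 2,3-difluorophenoxy compare in this series.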